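The source may report more compounds than this note shows. Statements on the series, on what has been measured and on what is new or still open speak of the compounds shown alone.

Readings in a functional assay on Caco-2 cells (Homo sapiens) for inhibition, read by sulforhodamine B assay, with a stated time of 48 h; on this read-out higher numbers stand for weaker inhibition and lower numbers for stronger inhibition:

- compound 1 `COC(=O)[C@@]1(C)C[C@@H](c2coc3ccc(Br)cc3c2=O)N(c2ccccc2)O1`: > 60000 nM
- compound 2 `CCO[C@H]1C[C@@H](c2coc3ccccc3c2=O)N(c2ccccc2)O1`: > 60000 nM
- compound 3 `O=C1[C@H]2[C@H](ON(c3ccccc3)[C@@H]2c2coc3ccc(F)cc3c2=O)C(=O)N1c1ccccc1`: > 60000 nM

Each of these readings is a limit and not a number. Compound 1 therefore has no measured potency, only its limit of > 60000 nM. The set as a whole rests on (the limit of > 60000 nM in this assay, at which 3 of the 3 values shown sit), so it gives no ranking of the three compounds.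

Compound 4 `COC(=O)[C@@]1(C)C[C@@H](c2coc3ccc(F)cc3c2=O)N(c2ccccc2)O1` has not yet been measured. It keeps the core of compound 1 and changes one group: fluoro in place of bromo on an aromatic carbon. This is fluoro in place of bromo on an aromatic carbon, meta to a fused ring and para to a fused ring.

No measured pair sizes this exchange. Compound 3 also carries fluoro, on a different core, and it too gives only a limit, > 60000 nM. On that basis, no step beyond the usual scatter is expected in this assay, and no direction is favoured. The expected change is a number no higher from compound 1 to compound 4 (the limit leaves the size open), an estimate anchored on a limit. The most likely outcome is another limit rather than a number.

For compound 4 the estimated value is 60000 nM, with an expected range from 30000 nM to 120000 nM.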

Compound 4, half-maximal inhibitory concentration: 29500 nM
Beside the measured number, compound 4's estimate is 2.0-fold (0.31 log units) above it, outside the stated range (below it).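

In this assay, fluoro in place of bromo on this aromatic carbon, meta to a fused ring and para to a fused ring, gives an at least 2.0-fold lower number from compound 1 to compound 4 (0.30 log units; that floor lies within the scatter). Going by these compounds alone, compound 4, at 29500 nM, holds the only reading in the set that is a number and not a limit, which shows that on the core of compound 1 a single exchange at this position can bring the reading within the measurable range. The true size of the step remains unknown, with only its floor printed, and the set otherwise offers little to scale it against: the limit of > 60000 nM in this assay, at which 3 of the 4 values shown sit.

Going by these compounds, whether chloro, a methoxy group or an amine on the same aromatic carbon would give a lower number than compound 4 remains open, and so does whether the fluoro exchange is the only one at this position that yields a measurable reading. Also open, on these data alone, is how the reading of compound 4 would respond if its methyl ester gave way to a carboxylic acid or an amide, or if the phenyl on the ring nitrogen carried a substituent.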